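A Methoxyphenyl Swap on Compound 1

The source may report more compounds than this note shows. Statements on the series, on what has been measured and on what is new or still open speak of the compounds shown alone.

In a functional assay on A-375 cells (Homo sapiens) for antiproliferative activity, read by MTT assay, with a stated time of 72 h (on this read-out lower numbers stand for stronger inhibition and higher numbers for weaker inhibition), compound 1 (`NC1CCc2nc(-c3ccncc3)nc(Nc3ccc(F)cc3)c2C1`) gives 12300 nM. Going by the values given here, the only other measured compound, compound 2 (`CN(C)c1ccc(Nc2nc(-c3ccncc3)nc3c2CC(N)CC3)cc1`), gives 12600 nM, so the two stand level and neither can be ranked above the other. The unmeasured compound 3 (`COc1cccc(Nc2nc(-c3ccncc3)nc3c2CC(N)CC3)c1`) keeps the shared core and changes one group: 3-methoxyphenyl in place of 4-fluorophenyl on a nitrogen on an aromatic ring. Among the compounds with values here, one measured step bears on this, a 1.0-fold higher number from compound 1 to compound 2 (0.01 log units; within the scatter), and it also alters the group carried on that nitrogen. Within the data shown here, no measured compound carries 3-methoxyphenyl, so this single step is only a thin guide. Even so, it gives no reason to expect a step beyond the scatter in this assay, in either direction. The estimated change is a 1.0-fold lower number from compound 1 to compound 3 (0.01 log units; within the scatter). For compound 3 the expected value is 12000 nM, within an estimated range of 5000 nM to 30000 nM.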

Compound 3, half-maximal inhibitory concentration: 15100 nM
Estimate against measurement, compound 3: 1.3-fold (0.10 log units) below, and the stated range covers the measured number.
By their numbers in this assay, from the lowest: compounds 1, 2 and 3 (each within the scatter of the next).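

On the nitrogen on an aromatic ring, 3-methoxyphenyl in place of 4-fluorophenyl gives a 1.2-fold higher number from compound 1 to compound 3 (0.09 log units; within the scatter), and 3-methoxyphenyl in place of 4-(dimethylamino)phenyl gives a 1.2-fold higher number from compound 2 to compound 3 (0.08 log units; within the scatter). So in this assay a third group at this place, the first shown that carries oxygen and a hydrogen-bond acceptor, leaves the number level with the other two, and the three groups cannot be told apart. Nothing at hand explains why these three groups stand level.

From the compounds shown here alone, whether a phenyl ring carrying a carboxylic acid or a nitrile, or a longer chain such as benzyl, would move the number beyond the scatter stays open. Also open, going by these compounds, is whether a change elsewhere on the shared core would shift the number more than these swaps on the nitrogen.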